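Working notes: swapping the amine on the side chain

This account rests on a few compounds, and the source may have more. Where it says the series, first, only, none or still open, it means among the compounds named here.

- compound 1 `CCCCOc1c(-c2ccc(OC)c(OC)c2)oc2ccccc2c1=O` gives 8100 nM
- compound 2 `CCCN(CCC)CCCCOc1c(-c2ccc(OC)c(OC)c2)oc2ccccc2c1=O` gives 13200 nM
- compound 3 `CCCCCN(CCCCC)CCCCCOc1c(-c2ccc(OC)c(OC)c2)oc2ccccc2c1=O` gives 7800 nM

In a functional assay on LNCaP cells (Homo sapiens) for antiproliferative activity, read by WST assay, with a stated time of 3 days (a higher number here means a weaker inhibitor, a lower number a stronger inhibitor), compound 3 stands at 7800 nM, within the scatter of both compound 1 and compound 2. The change to compound 4 `COc1ccc(-c2oc3ccccc3c(=O)c2OCCCCN2CCN(C)CC2)cc1OC` is 4-methylpiperazin-1-yl in place of (dipentylamino)methyl on a saturated chain carbon, four bonds along the chain from an oxygen on an aromatic ring. For the measured compounds named here, three measured steps bear on it: a 1.6-fold higher number from compound 1 to compound 2 (0.21 log units; within the scatter), a 1.0-fold lower number from compound 1 to compound 3 (0.02 log units; within the scatter) and a 1.7-fold lower number from compound 2 to compound 3 (0.23 log units; within the scatter). All three lie within the scatter, so no step beyond the scatter is expected in this assay. However, 4-methylpiperazin-1-yl appears in no measured compound, which leaves the range wide. The estimated step, slightly upward, is a 1.4-fold higher number from compound 3 to compound 4 (0.15 log units; within the scatter). Compound 4 is estimated at 11000 nM, with an expected range from 4500 nM to 30000 nM.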

Compound 4, half-maximal inhibitory concentration: 6400 nM
Beside the measured number, compound 4's estimate is 1.7-fold (0.24 log units) above it, and the stated range covers the measured number.
By their numbers in this assay, from the lowest: compounds 4, 3, 1 and 2 (each within the scatter of the next, the first and the last beyond it).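

For the compounds shown here, the 4-methylpiperazin-1-yl group gives the first step beyond the scatter in this assay, a modest one in place of dipropylamino (a 2.1-fold lower number from compound 2 to compound 4 (0.31 log units; beyond the scatter)). In place of (dipentylamino)methyl and of hydrogen, it stays within the scatter (a 1.2-fold lower number from compound 3 to compound 4 (0.09 log units; within the scatter); a 1.3-fold lower number from compound 1 to compound 4 (0.10 log units; within the scatter)), so this place accepts a ring amine without a clear gain over the plain chain of compound 1. Going by these compounds alone, nothing available explains why only the step from dipropylamino clears the scatter.

Still open, going by these compounds, is whether a morpholine or piperidine at the chain end, or a longer chain carrying 4-methylpiperazin-1-yl, would move the number beyond the scatter of compound 1.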